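The source may hold more compounds than are shown below. What is called first, only, known or untested is meant among the compounds shown, and "the series" means these compounds.

Series notes. Compound 1 `CN(Cc1ccccc1)C(=O)C1CCN(C(=O)c2ccc(S(C)(=O)=O)c([N+](=O)[O-])c2)CC1` is the reference amide. In an assay on isolated protein for inhibition of thyroid hormone receptor alpha (Homo sapiens), read by fluorescence polarization (on this read-out higher numbers stand for weaker inhibition and lower numbers for stronger inhibition), compound 1 gives > 60000 nM, which is a limit of the assay and not a number. Compound 2 `CN(Cc1ccccc1F)C(=O)C1CCN(C(=O)c2ccc(S(C)(=O)=O)c([N+](=O)[O-])c2)CC1` carries the change (fluoro in place of hydrogen on an aromatic carbon). In this assay compound 2 gives > 60000 nM, again a limit. The step that the two limits leave unreadable from compound 1 to compound 2 is therefore not readable, since both ends sit at the limit of > 60000 nM in this assay, at which 3 of the 3 values shown sit.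

Compound 3 `CN(Cc1ccccc1)C(=O)CNC(=O)c1ccc(S(C)(=O)=O)c([N+](=O)[O-])c1` has a different core; the difference between the core of compound 3 and the core of compound 1 is not broken down here. In this assay compound 3 gives > 60000 nM, a limit as well.

Compound 4 `CN(Cc1cccc(F)c1)C(=O)CNC(=O)c1ccc(S(C)(=O)=O)c([N+](=O)[O-])c1` is not yet measured. It differs from compound 3 by fluoro in place of hydrogen on an aromatic carbon. This is the same kind of change as that from compound 1 to compound 2, but the place differs: there the fluoro sits ortho to a large group, here meta to a large group.

The step that the limit leaves unreadable from compound 3 to compound 4 is expected to be small or unreadable, resting on the unreadable step that the two limits leave unreadable from compound 1 to compound 2 and on the limit shown by compound 3, > 60000 nM. Compound 4 is estimated at 80000 nM, most likely returned as a limit.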

Compound 4, half-maximal inhibitory concentration: > 60000 nM
Compound 4 gave a limit, no number; the forecaster's own chance of this, stated with the estimate: 85%; the middle value does not contradict the limit.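

Within the data shown here, compound 3 and compound 4 both sit at a limit and give no number, so no step between them can be read in this assay: the limit of > 60000 nM in this assay, at which 4 of the 4 values shown sit.

The compounds shown leave open how strongly any of the four inhibits, and whether fluoro in place of hydrogen on the benzyl group changes inhibition at all.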